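The compounds below may be only part of what the source reports. "The series", "measured", "known", "first", "only" and "open" are said of these compounds alone.

Of the compounds shown here, two with the same core have been measured in an ADME assay on the whole organism (Mus musculus, strain C57BL/6J) for pharmacokinetics, with a stated time of 24 h, at a dose of 2 mg/kg by the intravenous route; on this read-out lower numbers stand for slow clearance and higher numbers for fast clearance: compound 1 `CCCCOc1nc(OCC(C)(C)O)c(-c2ccc(S(C)(=O)=O)cc2)cc1CO` gives 101 mL/min/kg, and compound 2 `CCCCOc1nc(OCC2(O)COC2)c(-c2ccc(S(C)(=O)=O)cc2)cc1CO` gives 68.6 mL/min/kg. These two numbers lie within the usual scatter of repeated measurements, so compound 2 cannot be told apart from compound 1 on this read-out.

The next structure, compound 3 `CCCCOc1nc(OCC2(C)COC2)c(-c2ccc(S(C)(=O)=O)cc2)cc1CO`, alters a single group of compound 2: methyl in place of hydroxy on a saturated ring carbon. In words, this puts methyl in place of hydroxy on a saturated ring carbon.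

For the measured compounds named here, only one measured step bears on this change, a 1.5-fold lower number from compound 1 to compound 2 (0.17 log units; within the scatter). That step exchanged 1-hydroxy-1-methylethyl for 3-hydroxyoxetan-3-yl, and hydroxy was present on both sides of it. Going by the values given here, no measured step shows what happens when hydroxy leaves, so the data point in no direction here.

The expectation therefore stays close to the starting point, with no shift beyond the scatter. The expected step is a 1.1-fold higher number from compound 2 to compound 3 (0.04 log units; within the scatter). For compound 3 the estimated clearance is 75 mL/min/kg, with an expected range from 40 mL/min/kg to 130 mL/min/kg.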

Compound 3, clearance: 89.3 mL/min/kg
Compound 3: middle estimate off by 1.2-fold (0.08 log units), on the low side; the measured number falls inside the stated range.
By their numbers in this assay, from the lowest: compounds 2, 3 and 1 (each within the scatter of the next).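

In this assay, for the compounds shown here, the step of a 1.3-fold higher number from compound 2 to compound 3 (0.11 log units; within the scatter) is the first measured case in which the hydroxy on this saturated ring carbon leaves. Its loss, with methyl taking its place, takes away one hydrogen-bond donor and one hydrogen-bond acceptor, yet the clearance stays within the scatter, so this read-out does not separate the two groups at this position. The step of a 1.1-fold lower number from compound 1 to compound 3 (0.05 log units; within the scatter) is also within the scatter, which means that 3-methyloxetan-3-yl cannot be told apart from 1-hydroxy-1-methylethyl here, and no evidence is available on what lies behind these numbers.

The compounds shown carry only hydroxy or methyl on this ring carbon, so it remains open whether an amine, a carboxylic acid or a longer chain there would shift clearance beyond the scatter. As far as these compounds go, it also remains open whether the same exchange of hydroxy for methyl would stay within the scatter on a different alkoxy chain at the other end of the shared core, such as one shorter than the butoxy group these compounds carry.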